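Notes on the step from compound 2 to compound 3

The source may report more compounds than this note shows. Statements on the series, on what has been measured and on what is new or still open speak of the compounds shown alone.

Within the data shown here, in an ADME assay on HepG2 cells (Homo sapiens) for cytotoxicity, read by neutral red uptake, with a stated time of 24 h (a higher number here means a weaker inhibitor, a lower number a stronger inhibitor), compound 2 `CC(C)c1cc2c3c(c1OC(=O)c1cccnc1)OC(=O)[C@@]31CCCC(C)(C)[C@@H]1CC2` gives 264000 nM, the only actual number so far. Compound 1 `CCCCCCCCCCCC(=O)Oc1c(C(C)C)cc2c3c1OC(=O)[C@@]31CCCC(C)(C)[C@@H]1CC2` reports only a limit of the assay, > 1000000 nM.

Among the measured compounds shown here, the single measured step is an at least 3.7-fold lower number from compound 1 to compound 2 (0.57 log units; beyond the scatter). It starts from a limit, so its full size is not known. It concerns the same place as the next change, the substituent on a carbonyl carbon, but it removes an undecyl chain.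

Compound 3 `CC(C)c1cc2c3c(c1OC(=O)Cc1c[nH]c4ccccc14)OC(=O)[C@@]31CCCC(C)(C)[C@@H]1CC2` differs from compound 2 as follows: (1H-indol-3-yl)methyl in place of pyridin-3-yl on a carbonyl carbon. In words, (1H-indol-3-yl)methyl stands in place of pyridin-3-yl on a carbonyl carbon. No undecyl chain returns, and an aromatic group stays at this place, so the measured step is a poor guide to size. The data give no direction for this swap, and no step beyond the scatter is expected in this assay. The expected step is a 1.1-fold lower number from compound 2 to compound 3 (0.02 log units; within the scatter).

For compound 3 the estimated value is 250000 nM, with an expected range of 90000 nM to 800000 nM.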

Compound 3, half-maximal inhibitory concentration: 251000 nM
Compound 3: middle estimate off by 1.0-fold (0.00 log units), on the low side; the measured number falls inside the stated range.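

In this assay, the exchange at this place gives a 1.1-fold lower number from compound 2 to compound 3 (0.02 log units; within the scatter), so pyridin-3-yl and (1H-indol-3-yl)methyl on a carbonyl carbon cannot be told apart here, even though the entering group has 10 heavy atoms against 6, two aromatic rings against one, and a hydrogen-bond donor in place of a hydrogen-bond acceptor. Compound 1, with its undecyl chain, gives only a limit of the assay, > 1000000 nM. Read against that limit, the new step is an at least 3.9-fold lower number from compound 1 to compound 3 (0.60 log units; beyond the scatter), so a second aromatic group now stands apart from the undecyl chain in the same direction as pyridin-3-yl did, and the earlier step no longer rests on one compound alone.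

From the compounds shown here alone, whether an amine, a carboxylic acid or an alkyl chain shorter than undecyl on this carbonyl carbon would move the number beyond the scatter stays open. The full size of the gap from compound 1 to the two aromatic compounds also stays open, as the series holds one value that is not a number: the limit of > 1000000 nM in this assay, at which 1 of the 3 values shown sits.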